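Halogen loss at the aniline ring of the shared core

The source may report more compounds than this note shows. Statements on the series, on what has been measured and on what is new or still open speak of the compounds shown alone.

Measured compounds and their growth-inhibition values:
compound 1 `Cc1cc(-c2nc3cc(F)c(F)cc3s2)ccc1N`: > 100000 nM
compound 2 `Nc1ccc(-c2nc3cc(F)ccc3s2)cc1I`: 280 nM
compound 3 `Nc1ccc(-c2nc3ccc(F)cc3s2)cc1Cl`: 70 nM

In a functional assay on OVCAR-5 cells (Homo sapiens) for inhibition (a lower number here means a stronger inhibitor of growth, a higher number a weaker inhibitor of growth), compound 1 gives > 100000 nM, which is a limit of the assay and not a number (the limit of > 100000 nM in this assay, at which 1 of the 3 values shown sits). Compound 2 gives 280 nM in this assay, the highest of the two numbers shown, with compound 3 at 70 nM the nearest, a lower number beyond the scatter. Compound 4 `Nc1ccc(-c2nc3cc(F)ccc3s2)cc1` differs from compound 2 by hydrogen in place of iodo on an aromatic carbon. Among the compounds with values here, no measured step of this kind is available; removal of the halogen ortho to an amino group is expected to weaken growth inhibition, a step in this assay of roughly a 5.4-fold higher number from compound 2 to compound 4 (0.73 log units; beyond the scatter). Compound 4 is therefore estimated at 1500 nM, with a range from 200 nM to 15000 nM.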

Compound 4, concentration for 50% growth inhibition: 29500 nM
Compound 4: middle estimate off by 20-fold (1.29 log units), on the low side; measured number above the stated range.
By their numbers in this assay, from the lowest: compound 3; then compound 2; then compound 4. At a limit, above all of these: compound 1.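

In this assay, hydrogen in place of iodo ortho to an amino group gives a 110-fold higher number from compound 2 to compound 4 (2.02 log units; beyond the scatter). Within the data shown here, this is the first change that can be read at a single place, and it shows that growth inhibition depends strongly on what occupies this position. Nothing measured here gives a cause for the step.

Still open, as far as these compounds go, is whether iodo itself is required. Chloro, bromo, methyl or nitrile at this position on the core of compound 2 would show how much of the lost growth inhibition returns.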